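The compounds below may be only part of what the source reports. "The series", "measured", "known", "first", "only" and "open" are said of these compounds alone.

In an ADME assay on SNB-19 cells (Homo sapiens) for cytotoxicity, read by MTT assay, with a stated time of 24 h (a higher number here means that more compound is tolerated, a lower number that less compound is tolerated), compound 1 `C=C1CC[C@@H]2[C@](C)(CO)[C@H](O)CC[C@@]2(C)[C@@H]1C/C=C1/C(=O)OC[C@H]1Oc1c(Cl)cc(Cl)c2cccnc12` gives 85200 nM. Within the data shown here, the only other measured compound, compound 2 `C=C1CC[C@@H]2[C@](C)(COC(C)=O)[C@H](O)CC[C@@]2(C)[C@@H]1C/C=C1/C(=O)OC[C@H]1Oc1c(Cl)cc(Cl)c2cccnc12`, gives 88700 nM. These two values lie within the scatter of each other, so neither compound can be ranked against the other, and compound 1 stands level with compound 2 in this very small set.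

Compound 3 `C=C1CC[C@@H]2[C@](C)(CO)[C@H](O)CC[C@@]2(C)[C@@H]1C/C=C1/C(=O)OC[C@H]1Oc1ccnc2ccccc12` has not yet been measured in this assay. It keeps the core of compound 1 and carries quinolin-4-yl in place of 5,7-dichloroquinolin-8-yl on an oxygen on a saturated carbon. Among the measured compounds shown here, the one measured step, a 1.0-fold higher number from compound 1 to compound 2 (0.02 log units; within the scatter), belongs to a different change, acetyl in place of hydrogen on an oxygen on a saturated carbon, so it bears only weakly on this one. For the measured compounds named here, no measured pair varies the quinoline group, which leaves no basis for expecting a shift in either direction beyond the scatter, and the uncertainty stays wide. The estimated step is a 1.1-fold lower number from compound 1 to compound 3 (0.03 log units; within the scatter). Compound 3 is expected to give about 80000 nM, with an estimated range from 30000 nM to 200000 nM.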

Compound 3, half-maximal cytotoxic concentration: 60100 nM
The estimate for compound 3 lay 1.3-fold (0.12 log units) above the measured number, and the stated range covers the measured number.
By their numbers in this assay, from the lowest: compounds 3, 1 and 2 (each within the scatter of the next).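

The first measured variation of the quinoline group, quinolin-4-yl in place of 5,7-dichloroquinolin-8-yl on an oxygen on a saturated carbon, gives in this assay a 1.4-fold lower number from compound 1 to compound 3 (0.15 log units; within the scatter). So, in this assay, this oxygen can carry a quinoline with no chlorine atoms, joined through a different place in its name, and the number stays within the scatter of that for the dichloro group; the two compounds cannot be ranked. Nothing available offers an explanation for this result, so it stands as an observation only.

Because the swap removes both chlorine atoms and moves the point of attachment at once, the compounds shown cannot separate these two differences; quinolin-8-yl, which keeps the attachment of compound 1 without its chlorine atoms, would pull them apart. On these data alone, it also remains open whether a group of another kind on this oxygen, such as a plain phenyl or a short chain ending in an amine, would move the number beyond the scatter.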